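Swapping the aryl end of the acrylamide in compound 3

The source may report more compounds than this note shows. Statements on the series, on what has been measured and on what is new or still open speak of the compounds shown alone.

Of the compounds shown here, three sharing one core have been measured in a functional assay on HepG2 cells (Homo sapiens) for antiproliferative activity, read by MTT assay, with a stated time of 48 h; on this read-out lower numbers stand for stronger inhibition and higher numbers for weaker inhibition. Compound 1 `Clc1cccc(Nc2ncnc3ccc(NCc4c[nH]c5ccccc45)cc23)c1` gives 5260 nM, compound 2 `CSCCCNc1ccc2ncnc(Nc3cccc(Cl)c3)c2c1` gives 8920 nM, and compound 3 `O=C(/C=C/c1ncc2ccccc2n1)Nc1ccc2ncnc(Nc3cccc(Cl)c3)c2c1` gives 7790 nM. Within the data shown here, the one step between compounds that differ in a single place is a 1.7-fold higher number from compound 1 to compound 2 (0.23 log units; within the scatter), where a 2-(methylsulfanyl)ethyl group replaces 1H-indol-3-yl on a saturated chain carbon bound to a nitrogen on an aromatic ring. Compound 3 thus stands second highest of the three numbers, close to compound 2 and somewhat apart from compound 1, though all three lie within the scatter of one another.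

Compound 4 `Cc1cccc(/C=C/C(=O)Nc2ccc3ncnc(Nc4cccc(Cl)c4)c3c2)n1` has not yet been measured. It differs from compound 3 by 6-methylpyridin-2-yl in place of quinazolin-2-yl on a double-bonded chain carbon bound to a double-bonded chain carbon. Among the measured compounds shown here, no measured step touches this part of the molecule; the only step known, from compound 1 to compound 2, concerns the side chain on the nitrogen and stayed within the scatter. With nothing to indicate otherwise, the expectation for compound 4 in this assay is a number near that of compound 3, namely 7000 nM with a range from 2500 nM to 20000 nM. The expected step in this assay is a 1.1-fold lower number from compound 3 to compound 4 (0.05 log units; within the scatter), that is, none beyond the scatter.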

Compound 4, half-maximal inhibitory concentration: 4820 nM
Beside the measured number, compound 4's estimate is 1.5-fold (0.16 log units) above it; the range from low to high includes it.
By their numbers in this assay, from the lowest: compounds 4, 1, 3 and 2 (each within the scatter of the next).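

In this assay, the aryl end of the acrylamide tolerates a large change in structure while the two compounds stay within the scatter of each other: replacing quinazolin-2-yl with 6-methylpyridin-2-yl gives a 1.6-fold lower number from compound 3 to compound 4 (0.21 log units; within the scatter), the first step read at this place. The group that leaves has 10 heavy atoms in two aromatic rings, one of carbon only and one with 2 hetero atoms, while the group that enters has 7 heavy atoms in a single ring with 1 hetero atom, and this difference produces no step beyond the scatter on this read-out. No measurement is available that would explain this step.

The methyl group and the change of ring arrive together in this one step, and a plain pyridin-2-yl would be needed to tell their contributions apart. Also open, going by these compounds, is whether any group on a double-bonded chain carbon bound to a double-bonded chain carbon can move the number beyond the scatter in either direction, for instance a phenyl ring, or a pyridine ring carrying an amine or a carboxylic acid.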